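From pyridin-4-yl to furan-2-yl on the carbonyl carbon

This account rests on a few compounds, and the source may have more. Where it says the series, first, only, none or still open, it means among the compounds named here.

In a physicochemical assay for solubility, read by HPLC, with a stated time of 24 h (on this read-out higher numbers stand for higher solubility and lower numbers for lower solubility), compound 1 `CC(C)(C)c1[nH]cnc1/C=c1\[nH]c(=O)/c(=C/c2cccc(C(=O)N3CCC3)c2)[nH]c1=O` gives 4.23 ug/mL and compound 2 `CC(C)(C)c1[nH]cnc1/C=c1\[nH]c(=O)/c(=C/c2cccc(C(=O)N3CCCC3)c2)[nH]c1=O` gives 0.454 ug/mL. Compound 3 `CC(C)(C)c1[nH]cnc1/C=c1\[nH]c(=O)/c(=C/c2cccc(C(=O)c3ccncc3)c2)[nH]c1=O` reports only a limit, < 0.1 ug/mL. Compound 4 `CC(C)(C)c1[nH]cnc1/C=c1\[nH]c(=O)/c(=C/c2cccc(C(=O)c3ccco3)c2)[nH]c1=O` carries furan-2-yl in place of pyridin-4-yl on a carbonyl carbon. Three measured changes fall on that same carbonyl carbon: a 9.3-fold lower number from compound 1 to compound 2 (0.97 log units; beyond the scatter), an at least 42-fold lower number from compound 1 to compound 3 (1.62 log units; beyond the scatter) and an at least 4.5-fold lower number from compound 2 to compound 3 (0.65 log units; beyond the scatter). None of them exchanges one aromatic ring for another, so they guide the expectation only loosely. With an aromatic ring kept on the carbonyl carbon, no shift beyond the scatter is expected in this assay, and the expected step is a number no lower from compound 3 to compound 4 (the limit leaves the size open). Compound 4 is estimated at 0.1 ug/mL, with an expected range of 0.04 ug/mL to 0.4 ug/mL.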

Compound 4, solubility: < 0.1 ug/mL
Compound 4: a limit, no number; the forecaster's own chance of this, stated with the estimate: 60%; the middle value lies on the limit itself.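

In this assay compound 4 gives < 0.1 ug/mL, a limit and not a number. Furan-2-yl in place of pyrrolidin-1-yl and of azetidin-1-yl gives an at least 4.5-fold lower number from compound 2 to compound 4 (0.65 log units; beyond the scatter) and an at least 42-fold lower number from compound 1 to compound 4 (1.62 log units; beyond the scatter), so the low read-out is not confined to pyridin-4-yl. The step between the two aromatic rings cannot be read, because compound 3 and compound 4 both stand at one limit: the limit of < 0.1 ug/mL in this assay, at which 2 of the 4 values shown sit.

Any difference between furan-2-yl and pyridin-4-yl remains hidden under that limit. From the compounds shown here alone, whether a morpholin-4-yl or dimethylamino group on the carbonyl carbon would read nearer to compound 1 or to compound 2 stays open.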